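This account rests on a few compounds, and the source may have more. Where it says the series, first, only, none or still open, it means among the compounds named here.

In an ADME assay on HEL cells (Homo sapiens) for cytotoxicity, with a stated time of 3 days (a lower number here means that less compound is tolerated, a higher number that more compound is tolerated), compound 2 `Cc1cc(-c2ccsc2)c2ncc(CSCc3ccccc3)n2c1` gives 100 ug/mL, the higher of the two numbers measured. Compound 1 `Cc1cc(Sc2ccc(Cl)cc2)cn2c(CSCCc3ccccc3)cnc12` gives 14 ug/mL in this assay, and the gap between compound 1 and compound 2 lies beyond the usual scatter; the two structures differ in several places, so no single change can be tied to it. Compound 3 `Cc1cc(N2CCCC2)c2ncc(CSCc3ccccc3)n2c1` differs from compound 2 by pyrrolidin-1-yl in place of thiophen-3-yl on an aromatic carbon. Among the measured compounds shown here, no measured pair shows this change, so the expected step of a 1.1-fold lower number from compound 2 to compound 3 (0.05 log units; within the scatter) is one that stays within the scatter, in either direction. For compound 3 the expected value is 90 ug/mL, between 35 ug/mL and 200 ug/mL.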

Compound 3, half-maximal cytotoxic concentration: 52 ug/mL
Beside the measured number, compound 3's estimate is 1.7-fold (0.24 log units) above it; the range from low to high includes it.
By their numbers in this assay, from the lowest: compound 1; then compounds 3 and 2 (each within the scatter of the next).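

In this assay, pyrrolidin-1-yl in place of thiophen-3-yl on this aromatic carbon gives a 1.9-fold lower number from compound 2 to compound 3 (0.28 log units; within the scatter) and so shows no clear difference between these two five-membered rings at this position. Compound 1 could not show this, as it differs from compound 2 in several places. Nothing measured here speaks to why the two groups read alike. Still open, on these data alone, is whether an open-chain amine such as dimethylamino, or a carboxylic acid, on this carbon would stay within the same range. Also open, as far as these compounds go, is whether this result holds with a different side chain on the core.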